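The source may hold more compounds than are shown below. What is called first, only, known or untested is meant among the compounds shown, and "the series" means these compounds.

Measured so far in a functional assay on A549 cells (Homo sapiens) for inhibition, read by MTT assay, with a stated time of 72 h; on this read-out higher numbers stand for weaker inhibition and lower numbers for stronger inhibition:

Compound 1 `COc1cc(O)c(CC=C(C)C)c(O)c1C(=O)/C=C/c1ccc(Cl)cc1`; compound 1 gives 11800 nM.
Compound 2 `COc1cc(O)c(CC=C(C)C)c(O)c1C(=O)/C=C/c1ccc([N+](=O)[O-])cc1`; compound 2 gives 31200 nM.
Compound 3 `COc1cc(O)cc(O)c1C(=O)/C=C/c1ccc(Cl)cc1`; compound 3 gives 18200 nM.

The step from compound 1 to compound 2 is nitro in place of chloro on an aromatic carbon, and in this assay it made a 2.6-fold higher number from compound 1 to compound 2 (0.42 log units; beyond the scatter). Compound 3 stands next to compound 1 through (hydrogen in place of 3-methylbut-2-en-1-yl on an aromatic carbon), a change that made a 1.5-fold higher number from compound 1 to compound 3 (0.19 log units; within the scatter).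

Compound 4 `COc1cc(O)cc(O)c1C(=O)/C=C/c1ccc([N+](=O)[O-])cc1` has not yet been measured in this assay. Among the measured compounds shown here, it differs from compound 3 by nitro in place of chloro on an aromatic carbon, which is the same change as the one from compound 1 to compound 2; the place reads the same word for word in both pairs, and the cores differ only as described for compound 1 and compound 3. The change has been seen once among these compounds, so any transfer rests on that single pair.

For compound 4 a step of similar size is expected, a 2.5-fold higher number from compound 3 to compound 4 (0.39 log units; beyond the scatter), because the earlier pair gave a 2.6-fold higher number from compound 1 to compound 2 (0.42 log units; beyond the scatter) on a core that differs only modestly. Compound 4 is expected at 45000 nM, with a range of 24000 nM to 90000 nM.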

Compound 4, half-maximal inhibitory concentration: > 50000 nM
Compound 4 gave a limit, no number (the forecaster's own chance of this, stated with the estimate: 20%); at least 1.1-fold (0.04 log units) between middle value and limit.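

In this assay compound 4 gives > 50000 nM, which is a limit of the assay and not a number, so each step to it gives only a floor. Nitro in place of chloro gave an at least 2.7-fold higher number from compound 3 to compound 4 (0.43 log units; beyond the scatter), which shows that the direction of the change carries from the core of compound 1 to the core of compound 3 but does not show that its size carries: the same change on two cores in this assay, a 2.6-fold higher number (0.42 log units; beyond the scatter) from compound 1 to compound 2 and an at least 2.7-fold higher number (0.43 log units; beyond the scatter) from compound 3 to compound 4; the limit leaves it open whether they differ Hydrogen in place of 3-methylbut-2-en-1-yl gave an at least 1.6-fold higher number from compound 2 to compound 4 (0.20 log units; that floor lies within the scatter), and this floor shows neither that the change has the same size on the nitro and chloro compounds nor that it has a different one: the same change on two cores in this assay, a 1.5-fold higher number (0.19 log units; within the scatter) from compound 1 to compound 3 and an at least 1.6-fold higher number (0.20 log units; that floor lies within the scatter) from compound 2 to compound 4; the limit leaves it open whether they differ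

The compounds shown carry only chloro or nitro on this aromatic carbon, so it remains open whether an amine or a carboxylic acid there would follow the same direction on both cores. Going by these compounds, it also remains open how a longer chain in place of 3-methylbut-2-en-1-yl would read with either group.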